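A few compounds are considered here, and "the series" means these few. Any claim that something is new, unique, unknown or untested is made for them only; others in the source may bear on it.

Among the measured compounds shown here, compound 2 `N#Cc1ccc(Nc2nccc(OCc3ccccc3F)n2)cc1` gives 151000 nM in an ADME assay on MT4 cells (Homo sapiens) for cytotoxicity, read by MTT assay, with a stated time of 5 days (a lower number here means that less compound is tolerated, a higher number that more compound is tolerated), the lowest of the two numbers so far; its nearest neighbour is compound 1 `N#Cc1ccc(Nc2nccc(OCc3cccc(Br)c3)n2)cc1`, with 221000 nM in this assay, and the step of a 1.5-fold lower number from compound 1 to compound 2 (0.17 log units; within the scatter) lies within the scatter. Compound 3 `N#Cc1ccc(Nc2nccc(OCc3ccc(Br)cc3F)n2)cc1` differs from compound 2 by bromo in place of hydrogen on an aromatic carbon, read one bond further out as 2-fluorophenyl to 4-bromo-2-fluorophenyl. For the measured compounds named here, the only measured step, which also exchanged substituents on this ring, stayed within the scatter, so no step beyond the scatter is expected in this assay. Compound 3 is expected to give 170000 nM, range 80000 nM to 350000 nM, a step of a 1.1-fold higher number from compound 2 to compound 3 (0.05 log units; within the scatter).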

Compound 3, half-maximal cytotoxic concentration: 141000 nM
The estimate for compound 3 lay 1.2-fold (0.08 log units) above the measured number, within the range that was stated.
By their numbers in this assay, from the lowest: compounds 3, 2 and 1 (each within the scatter of the next).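

In this assay, bromo in place of hydrogen on the aromatic carbon para to a large group gives a 1.1-fold lower number from compound 2 to compound 3 (0.03 log units; within the scatter), so adding this atom to the 2-fluorophenyl ring produces no step beyond the scatter. The change from 3-bromophenyl to 4-bromo-2-fluorophenyl gives a 1.6-fold lower number from compound 1 to compound 3 (0.20 log units; within the scatter), which also stays within the scatter. No evidence at hand bears on this result.

Still open, as far as these compounds go, is whether an amine, a carboxylic acid or a longer chain at this ring position would give a step beyond the scatter. Also open, from the compounds shown here alone, is whether replacing the nitrile would do so.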